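Swapping the aryl group on the ring nitrogen of compound 3

The compounds below may be only part of what the source reports. "The series", "measured", "known", "first", "only" and "open" are said of these compounds alone.

Measured compounds and their values:
Compound 1, `CCC(=O)c1c(C)nn(CCCN2CCN(c3ccc(C)cc3)CC2)c(=O)c1N`, 29%
Compound 2, `CCCCC(=O)c1c(C)nn(CCCN2CCN(c3ccc(C)cc3)CC2)c(=O)c1N`, 15%
Compound 3, `Cc1c(C#N)c(-c2ccccc2)nn1CCCN1CCN(c2ccc(F)cc2)CC1`, 51%

Within the data shown here, in a functional assay on the whole organism (Abdomen, strain Swiss) for inhibition, with Mus musculus as the target, with stated times of 30 min, 10 min and 5 min, at a dose of 40 mg/kg by the oral route (on this read-out lower numbers stand for a weaker effect and higher numbers for a stronger effect at the one dose given), compound 3 gives the highest of the three numbers; no single-place step joins it to compound 1, so it is said plainly from the values: compound 1 lies a good way below it, and compound 2 lower still, both beyond the scatter. Compound 4, `COc1cccc(N2CCN(CCCn3nc(-c4ccccc4)c(C#N)c3C)CC2)c1`, has not yet been measured. It differs from compound 3 in one place: 3-methoxyphenyl in place of 4-fluorophenyl on an amine nitrogen in a ring.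

Among the measured compounds shown here, only one measured step exists, a number 14 percentage points lower from compound 1 to compound 2 (beyond the scatter), and it concerns a chain beside a carbonyl on a different core, so it says nothing about exchanging one aryl group for another on the ring nitrogen. For the measured compounds named here, with no step bearing on this change, no movement beyond the scatter is expected in this assay, in either direction. Compound 4 is therefore estimated at 45%, within 20% to 70%, which means an expected step of a number 6 percentage points lower from compound 3 to compound 4 (within the scatter).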

Compound 4, a percentage reported as inhibition, in the whole organism at one dose (the size of the read-out at that dose, not a potency): 34%
Estimate against measurement, compound 4: 11 percentage points above; measured number inside the range.
By their numbers in this assay, from the lowest: compound 2; then compounds 1 and 4 (each within the scatter of the next); then compound 3.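

In this assay, among these compounds, the aryl group on the amine nitrogen in the ring turns out to matter: putting 3-methoxyphenyl in place of 4-fluorophenyl gives a number 17 percentage points lower from compound 3 to compound 4 (beyond the scatter) at the one dose tested, whereas the only earlier step concerned a chain on a different core. This single exchange alters both the group carried on the phenyl ring and its ring position, and the result cannot separate these two changes. Nothing available here explains the lower number.

A 4-methoxyphenyl or 3-fluorophenyl group on the same nitrogen would help show whether the group or its ring position accounts for the step. On these data alone, it also remains open how an unsubstituted phenyl group or a pyridyl ring would compare in this position.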